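From 2-methoxyphenyl to 4-propylphenyl on an amine nitrogen

The compounds below may be only part of what the source reports. "The series", "measured", "known", "first", "only" and "open" are said of these compounds alone.

Compound 1 `O=C1C(Nc2ccccc2F)=CC(=O)c2c1nc1n2[C@H]2OC[C@@H](O)[C@H]2OC1` gives > 4000 nM as a limit
Compound 2 `Cc1ccc(NC2=CC(=O)c3c(nc4n3[C@H]3OC[C@@H](O)[C@H]3OC4)C2=O)cc1` gives > 4000 nM as a limit
Compound 3 `COc1ccccc1NC1=CC(=O)c2c(nc3n2[C@H]2OC[C@@H](O)[C@H]2OC3)C1=O` gives 6580 nM as a number

Compound 3 is the only one of the three with a number in a functional assay on MCF7 cells (Homo sapiens) for inhibition, read by sulforhodamine B assay (a higher number here means a weaker inhibitor, a lower number a stronger inhibitor), and that number is 6580 nM without any measured neighbour to rank it against. Compound 1 and compound 2 both stop at the limit of > 4000 nM in this assay, at which 2 of the 3 values shown sit, and remain limits.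

Compound 4 `CCCc1ccc(NC2=CC(=O)c3c(nc4n3[C@H]3OC[C@@H](O)[C@H]3OC4)C2=O)cc1` has not yet been measured. It carries 4-propylphenyl in place of 2-methoxyphenyl on an amine nitrogen, a change counted as 4-propylphenyl in place of 2-methoxyphenyl on an amine nitrogen and otherwise leaves the core of compound 3 untouched.

The measured step that bears most directly is a step that the limit leaves unreadable from compound 2 to compound 3, which links 4-methylphenyl to 2-methoxyphenyl but gives no size. The steps a step that the two limits leave unreadable from compound 1 to compound 2 and a step that the limit leaves unreadable from compound 1 to compound 3 are no more readable. With no measured size to carry over, no change beyond the scatter is expected in this assay in either direction, and the estimated step is a 1.1-fold lower number from compound 3 to compound 4 (0.04 log units; within the scatter) for that reason. Compound 4 is expected at 6000 nM, with an estimated range from 2500 nM to 14000 nM and a real chance of being reported only as a limit.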

Compound 4, half-maximal inhibitory concentration: > 4000 nM
Compound 4 gave a limit, no number (the forecaster's own chance of this, stated with the estimate: 50%); the middle value does not contradict the limit.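

In this assay compound 4 gives > 4000 nM, a limit. No step linking compound 4 to compound 1, compound 2 or compound 3 can be read: the limit of > 4000 nM in this assay, at which 3 of the 4 values shown sit.

The compounds shown leave open how these groups on the amine nitrogen rank against one another.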